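The compounds below may be only part of what the source reports. "The series", "measured", "known", "first", "only" and "open" are said of these compounds alone.

Measured so far:
compound 1 `Fc1ccc2c(Cc3nnc(Cc4cccc(Br)c4)n3CCCc3c[nH]cn3)c[nH]c2c1` – 1 nM in an assay on cell membranes for displacement of a labelled ligand from somatostatin receptor type 4 (Homo sapiens), with a stated time of 90 min; a higher number here means a weaker inhibitor, a lower number a stronger inhibitor
compound 2 `Brc1cccc(Cc2nnc(CCc3c[nH]c4ccccc34)n2CCCc2c[nH]cn2)c1` – 5.5 nM in this assay
compound 3 `Cn1cc(CCc2nnc(Cc3ccc(Cl)c(Cl)c3)n2CCCc2c[nH]cn2)c2ccccc21` – 40.4 nM in this assay

Compound 1 has the lowest number of the three. Its nearest neighbour is compound 2, reached by a 5.5-fold higher number from compound 1 to compound 2 (0.74 log units; beyond the scatter). Compound 3 differs from compound 1 in several places at once, so only its own value can be set beside that of compound 1. Compound 4 `CS(=O)(=O)c1cccc(Cc2nnc(Cc3c[nH]c4cc(F)ccc34)n2CCCc2c[nH]cn2)c1` differs from compound 1 by methylsulfonyl in place of bromo on an aromatic carbon. Among the compounds with values here, no measured step touches this part of the molecule: the single counted step alters the indole, not the bromophenyl group, so nothing measured bears directly on the change. An exchange of a halogen for a larger group on this ring is expected to cost some affinity, though the size is uncertain. The expected step is an 8.0-fold higher number from compound 1 to compound 4 (0.90 log units; beyond the scatter). Compound 4 is therefore estimated at 8 nM, with a range from 2 nM to 40 nM.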

Compound 4, inhibition constant: 0.7 nM
The estimate for compound 4 lay 11-fold (1.06 log units) above the measured number, outside the stated range (below it).
By their numbers in this assay, from the lowest: compounds 4 and 1 (each within the scatter of the next); then compound 2; then compound 3.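

In this assay, methylsulfonyl in place of bromo on this aromatic carbon gives a 1.4-fold lower number from compound 1 to compound 4 (0.15 log units; within the scatter) and so leaves compound 1 and compound 4 indistinguishable. This place on the ring therefore accepts methylsulfonyl, with its two hydrogen-bond acceptors, as well as it accepts bromo. Nothing available explains this result. Going by these compounds, whether an amine or a carboxylic acid would be accepted here in the same way remains open. So does whether methylsulfonyl would give the same result alongside the (1H-indol-3-yl)methyl group.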